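Swapping the indazole for a pyrazolopyridine in a diaryl urea

The source may hold more compounds than are shown below. What is called first, only, known or untested is meant among the compounds shown, and "the series" means these compounds.

Three diaryl ureas were tested in a functional assay on A549 cells (Homo sapiens) for cytotoxicity, read by MTT assay, with a stated time of 72 h; on this read-out lower numbers stand for stronger inhibition and higher numbers for weaker inhibition. Compound 1 `O=C(Nc1ccc(-n2ncc3c(Cl)cccc32)cc1)Nc1ccc(Cl)c(C(F)(F)F)c1` gives 3100 nM, compound 2 `O=C(Nc1ccc(-n2ncc3c(F)cccc32)cc1)Nc1ccc(Cl)c(C(F)(F)F)c1` gives 3800 nM, and compound 3 `Cc1cccc2c1cnn2-c1ccc(NC(=O)Nc2ccc(Cl)c(C(F)(F)F)c2)cc1` gives 5500 nM. Compound 3 carries the largest number of the three, yet the steps of a 1.8-fold higher number from compound 1 to compound 3 (0.25 log units; within the scatter) and a 1.4-fold higher number from compound 2 to compound 3 (0.16 log units; within the scatter) are within the scatter, as is a 1.2-fold higher number from compound 1 to compound 2 (0.09 log units; within the scatter), so the three compounds are not separated on this read-out.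

Compound 4 `O=C(Nc1ccc(-n2ncc3cnccc32)cc1)Nc1ccc(Cl)c(C(F)(F)F)c1` differs from compound 3 by a group of 9 heavy atoms (6 carbon, 3 nitrogen; one five-membered aromatic ring with 2 hetero atoms, one six-membered aromatic ring with 1 hetero atom) in place of a group of 10 heavy atoms (8 carbon, 2 nitrogen; one five-membered aromatic ring with 2 hetero atoms, one six-membered aromatic ring of carbon only), on an aromatic carbon. Among the compounds with values here, none of the measured steps bears on this change: each of them exchanged one small substituent on the carbon-only six-membered ring of the bicycle, whereas here a ring nitrogen enters and the methyl leaves. Within the data shown here, the data therefore give no direction for the step, and the prior expectation is that a 1.1-fold higher number from compound 3 to compound 4 (0.04 log units; within the scatter) will fall within the scatter. Compound 4 is estimated at 6000 nM in this assay, with a range from 2500 nM to 15000 nM.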

Compound 4, half-maximal inhibitory concentration: 3400 nM
Estimate against measurement, compound 4: 1.8-fold (0.25 log units) above, within the range that was stated.
By their numbers in this assay, from the lowest: compounds 1, 4, 2 and 3 (each within the scatter of the next).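

In this assay, the step that brings a ring nitrogen into the six-membered ring and removes the substituent stays within the scatter against all three earlier compounds: a 1.6-fold lower number from compound 3 to compound 4 (0.21 log units; within the scatter), a 1.1-fold lower number from compound 2 to compound 4 (0.05 log units; within the scatter), and a 1.1-fold higher number from compound 1 to compound 4 (0.04 log units; within the scatter). The earlier steps shown here covered only exchanges among chloro, fluoro and methyl on a carbon-only ring, whereas these show that changing the ring itself also leaves the four compounds unseparated on this read-out. No available evidence accounts for this result.

The compounds shown leave open whether a larger or ionisable group at this place, such as an amine, a carboxylic acid or a morpholine, would separate from these four. They also leave open whether a ring nitrogen combined with chloro, fluoro or methyl would do so.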